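Ethylamino in place of methyl on the pyrazolopyrimidine core

This account rests on a few compounds, and the source may have more. Where it says the series, first, only, none or still open, it means among the compounds named here.

Compound 1 `Cn1ncc2c(NS(=O)(=O)c3cccc(Cl)c3Cl)ccnc21`: 12600 nM
Compound 2 `CNC(=O)Cn1nc(OC)c2c(NS(=O)(=O)c3cccc(Cl)c3Cl)ncnc21`: 631 nM
Compound 3 `COc1nn(C)c2nc(C)nc(NS(=O)(=O)c3cccc(Cl)c3Cl)c12`: 631 nM

In a functional assay on cells for antagonist activity at C-C chemokine receptor type 4 (Homo sapiens), read by GTPgammaS binding (on this read-out lower numbers stand for stronger inhibition and higher numbers for weaker inhibition), compound 3 stands level with compound 2, the two together at the lowest numbers of the three; compound 1 lies well above both, beyond the scatter.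

Compound 4 `CCNc1nc(NS(=O)(=O)c2cccc(Cl)c2Cl)c2c(OC)nn(C)c2n1` differs from compound 3 by a single change: ethylamino in place of methyl on an aromatic carbon. Within the data shown here, no pair of measured compounds shows this exact exchange, so the size of the step cannot be read from the numbers at hand.

Since compound 2 and compound 3 sit at the same level despite different groups elsewhere on the shared core, a modest step is expected here, tending toward stronger inhibition and roughly at the edge of the scatter, a 2.1-fold lower number from compound 3 to compound 4 (0.32 log units; beyond the scatter). Compound 4 is therefore estimated at 300 nM, within a range from 60 nM to 2000 nM.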

Compound 4, half-maximal inhibitory concentration in the C-C chemokine receptor type 4 assay: 251 nM
The estimate for compound 4 lay 1.2-fold (0.08 log units) above the measured number, within the range that was stated.
By their numbers in the C-C chemokine receptor type 4 assay, from the lowest: compound 4; then compounds 2 and 3 (each within the scatter of the next); then compound 1.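

In the C-C chemokine receptor type 4 assay, ethylamino in place of methyl on an aromatic carbon between two ring nitrogen atoms gives a 2.5-fold lower number from compound 3 to compound 4 (0.40 log units; beyond the scatter), so this position of the shared core accepts a larger group carrying a hydrogen-bond donor, with stronger inhibition. In a physicochemical assay for lipophilicity (a higher number here means a more lipophilic compound, a lower number a more polar compound), compound 3 gives 3.4 and compound 4 gives 4.2. The same exchange also makes the compound more lipophilic in the physicochemical assay: the measured distribution coefficient of compound 3, 3.4, and of compound 4, 4.2, a number 0.80 log units higher (beyond the scatter)

The compounds shown leave open whether the stronger inhibition goes with the amino nitrogen or with the added carbon atoms. A plain ethyl group or an unsubstituted amine at this position would separate the two.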